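This account rests on a few compounds, and the source may have more. Where it says the series, first, only, none or still open, it means among the compounds named here.

Compound 1 `O=C(CCSc1ccc2c(/C=C/c3ccccn3)n[nH]c2c1)Nc1ccccc1`: 690 nM
Compound 2 `O=C(CCSc1ccc2c(/C=C/c3ccccn3)n[nH]c2c1)Nc1cccc(F)c1`: 6590 nM
Compound 3 `CN(C)c1cccc(NC(=O)CCSc2ccc3c(/C=C/c4ccccn4)n[nH]c3c2)c1`: > 10000 nM, a limit of the assay

These values come from an ADME assay on BaF3 cells (Mus musculus) for antiproliferative activity, read by CCK-8 assay, with a stated time of 72 h; on this read-out higher numbers stand for weaker inhibition of growth and lower numbers for stronger inhibition of growth. Compound 3 stands only at a limit, > 10000 nM, and not at a number. The next compound, compound 4 `Cc1ccc(NC(=O)CCSc2ccc3c(/C=C/c4ccccn4)n[nH]c3c2)cc1`, changes one part of compound 3: 4-methylphenyl in place of 3-(dimethylamino)phenyl on an amide-type nitrogen.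

Within the data shown here, no methyl-bearing compound has been measured, so the closest guides are the two steps away from compound 1. These are a 9.6-fold higher number from compound 1 to compound 2 (0.98 log units; beyond the scatter) and an at least 14-fold higher number from compound 1 to compound 3 (1.16 log units; beyond the scatter). Both are beyond the scatter and both lead to higher numbers, so a new group on this ring has so far never helped. The comparison an at least 1.5-fold higher number from compound 2 to compound 3 (0.18 log units; that floor lies within the scatter) adds little, as its floor lies within the scatter.

Compound 4 is therefore expected to read below the limit of compound 3. Compound 4 is still expected to read probably above compound 1 at 690 nM. The expected change is an at least 3.3-fold lower number from compound 3 to compound 4 (0.52 log units; beyond the scatter), towards stronger inhibition of growth. The estimate for compound 4 is 3000 nM, with an expected range of 800 nM to 10000 nM.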

Compound 4, concentration for 50% growth inhibition: > 10000 nM
Compound 4: no number, only a limit (the forecaster's own chance of this, stated with the estimate: 15%); at least 3.3-fold (0.52 log units) between middle value and limit.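

In this assay, methyl in place of hydrogen on the aromatic ring gives an at least 14-fold higher number from compound 1 to compound 4 (1.16 log units; beyond the scatter). The new result adds a third case: compound 2, compound 3 and compound 4 each carry a group on this ring, and each reads higher than compound 1, with no compound shown going against this. Compared with compound 2 there is an at least 1.5-fold higher number from compound 2 to compound 4 (0.18 log units; that floor lies within the scatter), and as that floor lies within the scatter, it sets no order between the two compounds, while the step between compound 3 and compound 4 cannot be read because both sit at a limit of the assay: the limit of > 10000 nM in this assay, at which 2 of the 4 values shown sit.

From the compounds shown here alone, how far compound 3 and compound 4 actually lie beyond that limit remains open. Also open, going by these compounds, is whether any other group on this ring, such as a methoxy group or a carboxylic acid, could match or improve on compound 1.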